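This account rests on a few compounds, and the source may have more. Where it says the series, first, only, none or still open, it means among the compounds named here.

Measured so far:
Compound 1 `Oc1cc(O)cc(-c2cn(-c3ccc(OC(F)(F)F)cc3)nn2)c1` in a functional assay on MDA-MB-231 cells (Homo sapiens) for cytotoxicity, read by MTT assay (a higher number here means a weaker inhibitor, a lower number a stronger inhibitor), gives > 10000 nM, a limit of the assay.
Compound 2 `Nc1ccc(-c2cn(-c3ccc(Oc4ccccc4)cc3)nn2)cc1` in this assay gives > 10000 nM, also a limit.

Compound 2 stands only at a limit, and the limit of > 10000 nM in this assay, at which 2 of the 2 values shown sit, holds for every value shown. Compound 3 `Oc1cc(O)cc(-c2cn(-c3ccc(Oc4ccccc4)cc3)nn2)c1` is not yet measured in this assay; it differs from compound 2 in one place: 3,5-dihydroxyphenyl in place of 4-aminophenyl on an aromatic carbon. No measured step is shown between compounds, so nothing indicates what size of step to expect in this assay, and the step from compound 2 would start from a limit. Compound 3 is expected to stay near that limit, estimated at 15000 nM (range 5000 nM to 60000 nM). The step that the limit leaves unreadable from compound 2 to compound 3 is expected to be none beyond the scatter.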

Compound 3, half-maximal inhibitory concentration: > 10000 nM
Compound 3: no number, only a limit (the forecaster's own chance of this, stated with the estimate: 75%); the middle value is on the limit's open side.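

In this assay no step can be read among compound 1, compound 2 and compound 3, all three standing at a limit: the limit of > 10000 nM in this assay, at which 3 of the 3 values shown sit. The compounds shown leave open whether any change on the shared core gives a readable value in this assay.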